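The source may report more compounds than this note shows. Statements on the series, on what has been measured and on what is new or still open speak of the compounds shown alone.

Going by the values given here, compound 2 `C/C(=N\OC(c1ccc(OCc2ccc3ccccc3n2)cc1)C1CCCC1)C(=O)O` gives 16 nM in a functional assay for inhibition of Polyunsaturated fatty acid 5-lipoxygenase (Homo sapiens) (a lower number here means a stronger inhibitor, a higher number a weaker inhibitor), the higher of the two numbers known here, yet within the scatter of compound 1 `CCCCC(CCCC)C(O/N=C(\C)C(=O)O)c1ccc(OCc2ccc3ccccc3n2)cc1`, which gives 14 nM in this assay. Among the compounds with values here, the only step that bears on what comes next is a 1.1-fold higher number from compound 1 to compound 2 (0.06 log units; within the scatter), where 1-butylpentyl gave way to cyclopentyl. Compound 3 `C/C(=N\OC(c1ccc(OCc2ccc3ccccc3n2)cc1)C1CCCCCC1)C(=O)O` differs from compound 2 by cycloheptyl in place of cyclopentyl on a saturated chain carbon bound to an aromatic carbon and an oxygen. Because that earlier swap of groups at the same place produced a 1.1-fold higher number from compound 1 to compound 2 (0.06 log units; within the scatter), the step of no change at the digits printed from compound 2 to compound 3 (within the scatter) is expected to stay within the scatter, in no clear direction. Compound 3 is therefore estimated at 16 nM, with a range from 6 nM to 45 nM.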

Compound 3, half-maximal inhibitory concentration: 13 nM
For compound 3 the middle estimate is 1.2-fold (0.09 log units) above the measured one, within the range that was stated.
By their numbers in this assay, from the lowest: compounds 3, 1 and 2 (each within the scatter of the next).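

In this assay, the swap to cycloheptyl on this saturated chain carbon reads as a 1.2-fold lower number from compound 2 to compound 3 (0.09 log units; within the scatter) and as a 1.1-fold lower number from compound 1 to compound 3 (0.03 log units; within the scatter). A ring of seven carbons therefore now joins cyclopentyl and the open-chain 1-butylpentyl, and all three groups give numbers within the scatter of one another. No measurement on hand explains this sameness. On these data alone, all three groups are built of carbon and hydrogen alone and are non-aromatic, so it remains open whether a much smaller methyl, an aromatic phenyl or a group carrying an amine at this place would read the same.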